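The source may hold more compounds than are shown below. What is called first, only, known or untested is meant among the compounds shown, and "the series" means these compounds.

Working notes on the series. In a functional assay on HCT-116 cells (Homo sapiens) for antiproliferative activity, read by MTT assay, with a stated time of 48 h (on this read-out lower numbers stand for stronger inhibition of growth and higher numbers for weaker inhibition of growth), compound 1 (`Cc1ccc(-c2cnc(N(Cc3ccc(C(=O)NO)cc3)CC(C)C)s2)cc1`) gives 5900 nM. Among the measured compounds shown here, compound 2 (`Cc1ccc(-c2cnc(N(CCCOc3ccccc3)Cc3ccc(C(=O)NO)cc3)s2)cc1`) gives 4140 nM, which places the only two numbers so far within the scatter of each other. The next structure, compound 3 (`CCCN(Cc1ccc(C(=O)NO)cc1)c1ncc(-c2ccc(C)cc2)s1`), is not yet measured. The change is hydrogen in place of phenoxy on a saturated chain carbon, three bonds along the chain from a nitrogen on an aromatic ring, so 3-phenoxypropyl becomes propyl. For the measured compounds named here, the one measured step also alters the chain on that nitrogen, putting 2-phenoxyethyl in place of isopropyl, and it is a 1.4-fold lower number from compound 1 to compound 2 (0.15 log units; within the scatter). On this single step, no change beyond the scatter is expected in this assay. The expected step is a 1.2-fold higher number from compound 2 to compound 3 (0.08 log units; within the scatter). For compound 3 the estimated value is 5000 nM, with an expected range of 2500 nM to 10000 nM.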

Compound 3, concentration for 50% growth inhibition: 5800 nM
Estimate against measurement, compound 3: 1.2-fold (0.06 log units) below, within the range that was stated.
By their numbers in this assay, from the lowest: compounds 2, 3 and 1 (each within the scatter of the next).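

In this assay, hydrogen in place of phenoxy on a saturated chain carbon, three bonds along the chain from a nitrogen on an aromatic ring, gives a 1.4-fold higher number from compound 2 to compound 3 (0.15 log units; within the scatter), so losing a six-membered aromatic ring of carbon only from this place, with 3-phenoxypropyl becoming propyl, leaves the number within the scatter. Hydrogen in place of methyl on a saturated chain carbon bound to two saturated chain carbons gives a 1.0-fold lower number from compound 1 to compound 3 (0.01 log units; within the scatter), so this second change to the chain also stays within the scatter, and the three chains cannot be told apart on this read-out. No measured evidence bears on why these chains give such close numbers.

The compounds shown leave open whether any group on this chain moves the number beyond the scatter. An amine or a carboxylic acid in place of phenoxy, or a chain longer than 3-phenoxypropyl, remains an open case.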